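The source may report more compounds than this note shows. Statements on the series, on what has been measured and on what is new or still open speak of the compounds shown alone.

Measured compounds:
compound 1, `CC(=O)N[C@H]1[C@@H](OCc2ccccc2)O[C@H](CO)[C@@H](O)[C@@H]1O` — in a functional assay on U-373MG ATCC cells (Homo sapiens), read by thymidine incorporation (on this read-out higher numbers stand for weaker inhibition and lower numbers for stronger inhibition), compound 1 gave > 50 uM, a limit of the assay
compound 2, `CC(=O)N[C@H]1[C@@H](OCCc2ccccc2)O[C@H](CO)[C@@H](O)[C@@H]1O` — in this assay compound 2 gave > 50 uM, a limit of the assay

Compound 2 therefore stands at the limit, not at a number, and the same holds for the other value shown, as the limit of > 50 uM in this assay, at which 2 of the 2 values shown sit, records. The step that the two limits leave unreadable from compound 1 to compound 2 is accordingly unreadable.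

Compound 3, `C=CCCC(=O)N[C@H]1[C@@H](OCCc2ccccc2)O[C@H](CO)[C@@H](O)[C@@H]1O`, differs from compound 2 by allyl in place of hydrogen on a saturated chain carbon bound to a carbonyl carbon. No measured step bears on this change: the only step shown, from compound 1 to compound 2, concerns a different part of the molecule and could not be read in any case. There is thus no ground on which to expect a step in this assay of any particular size or direction. Compound 3 is expected to sit again at the limit, with an estimated step of a number no higher from compound 2 to compound 3 (the limit leaves the size open). The estimate for compound 3 is 50 uM, within 15 uM to 200 uM.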

Compound 3, concentration for 50% inhibition: > 50 uM
Compound 3 gave a limit, no number; the forecaster's own chance of this, stated with the estimate: 80%; the middle value sits exactly at the limit.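

Compound 2 and compound 3 both stand at a limit in this assay, and no step between them can be read: the limit of > 50 uM in this assay, at which 3 of the 3 values shown sit.

The compounds shown leave open what but-3-en-1-yl in place of methyl does to the inhibition, and whether any change to the shared core would give a number rather than a limit.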